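Triazole aryl swap and cytotoxicity in the sulfonamide series

The source may report more compounds than this note shows. Statements on the series, on what has been measured and on what is new or still open speak of the compounds shown alone.

Compound 3 `Cc1cccc(-n2cc(-c3ccc(NS(=O)(=O)c4c[nH]c(=O)[nH]c4=O)cc3)nn2)c1` gives 39000 nM in an ADME assay on L02 cells (Homo sapiens) for cytotoxicity, read by MTT assay, with a stated time of 24 h (on this read-out lower numbers stand for higher toxicity in this test and higher numbers for lower toxicity in this test), the highest of the two numbers in hand. Compound 2 `O=c1[nH]cc(S(=O)(=O)Nc2ccccc2-c2cn(-c3ccc(Cl)cc3)nn2)c(=O)[nH]1` gives 16800 nM in this assay. Compound 1 `O=c1[nH]cc(S(=O)(=O)Nc2ccccc2-c2cn(-c3cccc(Cl)c3)nn2)c(=O)[nH]1` reaches only the limit > 100000 nM in this assay. The change 2-fluorophenyl in place of 3-methylphenyl on an aromatic nitrogen yields compound 4 `O=c1[nH]cc(S(=O)(=O)Nc2ccc(-c3cn(-c4ccccc4F)nn3)cc2)c(=O)[nH]1`. Among the compounds with values here, no measured step matches this exchange; the only step at this position, an at least 5.9-fold lower number from compound 1 to compound 2 (0.77 log units; beyond the scatter), moves a chloro substituent and rests on the limit (the limit of > 100000 nM in this assay, at which 1 of the 3 values shown sits), so its size is a floor rather than a number. Within the data shown here, with no counterpart for exchanging 3-methylphenyl for 2-fluorophenyl, the step is expected to come out as a 1.1-fold lower number from compound 3 to compound 4 (0.05 log units; within the scatter), within the scatter. Compound 4 is estimated at 35000 nM, with a range from 12000 nM to 100000 nM.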

Compound 4, half-maximal cytotoxic concentration: > 100000 nM
Compound 4: only a limit was reported; the forecaster's own chance of this, stated with the estimate: 15%; middle value at least 2.8-fold (0.45 log units) away from the limit.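

In this assay, exchanging the aryl group on this aromatic nitrogen can also raise the number: an at least 2.5-fold higher number from compound 3 to compound 4 (0.40 log units; beyond the scatter). The earlier step at this position, an at least 5.9-fold lower number from compound 1 to compound 2 (0.77 log units; beyond the scatter), ran the other way, so the direction is not fixed across the compounds shown. Compound 4 gives > 100000 nM, which is a limit and not a number, so the size of its step is only a floor: the limit of > 100000 nM in this assay, at which 2 of the 4 values shown sit.

As far as these compounds go, it remains open how much of the step belongs to the fluorine and how much to the loss of the methyl. From the compounds shown here alone, how an amine or a carboxylic acid on this phenyl group would read in this assay also remains open.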